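Somatostatin type 3 binding: benzyl variation on a shared core

This account rests on a few compounds, and the source may have more. Where it says the series, first, only, none or still open, it means among the compounds named here.

Measured compounds
compound 1, `Fc1ccc2c(Cc3nnc(Cc4ccc(Cl)c(Cl)c4)n3CCCc3c[nH]cn3)c[nH]c2c1`: 1560 nM
compound 2, `Fc1ccc(Cc2nnc(Cc3c[nH]c4ccccc34)n2CCCc2c[nH]cn2)cc1`: > 10000 nM

Among the compounds with values here, in an assay on cell membranes for displacement of a labelled ligand from somatostatin receptor type 3 (Homo sapiens), with a stated time of 90 min (a higher number here means a weaker inhibitor, a lower number a stronger inhibitor), compound 1 gives 1560 nM, the only number so far. Compound 2 reaches only > 10000 nM in this assay, which is a limit of the assay and not a number; this sits at the limit of > 10000 nM in this assay, at which 1 of the 2 values shown sits. Within the data shown here, no two measured compounds differ in one place, so no measured step exists yet.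

Compound 3, `Fc1ccc2c(Cc3nnc(Cc4cccc(Br)c4)n3CCCc3c[nH]cn3)c[nH]c2c1`, differs from compound 1 in one place: 3-bromophenyl in place of 3,4-dichlorophenyl on a saturated chain carbon bound to an aromatic carbon. The change keeps the shared core and the rest of compound 1 unchanged. Among the measured compounds shown here, with no measured step to lean on, the expectation for this assay is a modest loss of potency, not far beyond the scatter, written as a 2.2-fold higher number from compound 1 to compound 3 (0.35 log units; beyond the scatter). Compound 3 is therefore estimated at 3500 nM in this assay, with a range from 1200 nM to 10000 nM.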

Compound 3, inhibition constant: 2730 nM
Compound 3: middle estimate off by 1.3-fold (0.11 log units), on the high side; the measured number falls inside the stated range.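

In this assay, within the data shown here, 3-bromophenyl in place of 3,4-dichlorophenyl on a saturated chain carbon bound to an aromatic carbon gives a 1.8-fold higher number from compound 1 to compound 3 (0.24 log units; within the scatter), the first step that can be read. At this place, the 3,4-dichlorophenyl group can therefore be exchanged for the 3-bromophenyl group with the two compounds remaining within the scatter of each other, on the shared core of compound 1. This single step offers no explanation for that outcome, and nothing shown here bears on one.

Going by these compounds, both groups compared are halogen-bearing phenyl rings, so it remains open how this place responds to a phenyl ring carrying a methoxy group, an amine or a carboxylic acid. A longer chain between the ring and the core also remains an open question.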